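Bicyclic amide replacement: from compound 3 to compound 4

The source may hold more compounds than are shown below. What is called first, only, known or untested is meant among the compounds shown, and "the series" means these compounds.

Among the measured compounds shown here, compound 3 `O=C(Nc1cnc2[nH]ncc2c1)[C@H]1CCCN1C(=O)C1(c2cccc(Cl)c2)CCCC1` gives 15.9 nM in an assay on isolated protein for inhibition of histone acetyltransferase p300 (Homo sapiens), with a stated time of 60 min (on this read-out higher numbers stand for weaker inhibition and lower numbers for stronger inhibition), the highest of the three numbers so far. Compound 1 `COc1ccc(NC(=O)[C@H]2CCCN2C(=O)C2(c3cccc(Cl)c3)CCCC2)nc1` gives 2 nM in this assay, and compound 2 `O=C(Nc1ccc2[nH]ncc2n1)[C@H]1CCCN1C(=O)C1(c2cccc(Cl)c2)CCCC1` gives 0.159 nM. The two measured steps into compound 3 are both beyond the scatter: an 8.0-fold higher number from compound 1 to compound 3 (0.90 log units; beyond the scatter) and a 100-fold higher number from compound 2 to compound 3 (2.00 log units; beyond the scatter), while a 13-fold lower number from compound 1 to compound 2 (1.10 log units; beyond the scatter) shows that one bicyclic amide substituent can also strengthen inhibition strongly.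

Compound 4 `O=C(Nc1ccc2[nH]nnc2c1)[C@H]1CCCN1C(=O)C1(c2cccc(Cl)c2)CCCC1` differs from compound 3 by a group of 9 heavy atoms (6 carbon, 3 nitrogen; one five-membered aromatic ring with 3 hetero atoms, one six-membered aromatic ring of carbon only) in place of a group of 9 heavy atoms (6 carbon, 3 nitrogen; one five-membered aromatic ring with 2 hetero atoms, one six-membered aromatic ring with 1 hetero atom), on an amide-type nitrogen. The same atoms are present but joined differently: the six-membered ring carrying the amide nitrogen is now carbon only, and the five-membered ring holds all three nitrogens.

The steps from compound 1 and compound 2 to compound 3 show that rearranging this bicycle changes the number by large amounts in either direction, so the step to compound 4 is uncertain. Compound 4 keeps, as compound 3 does, an amide nitrogen on a ring without the feature shared by compound 1 and compound 2, so a number near that of compound 3 is expected, with a 1.3-fold higher number from compound 3 to compound 4 (0.10 log units; within the scatter) as the estimated step. For compound 4 the expected value in this assay is 20 nM, within 5 nM to 80 nM.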

Compound 4, half-maximal inhibitory concentration: 20 nM
Estimate against measurement, compound 4: no gap at the digits printed; the measured number falls inside the stated range.
By their numbers in this assay, from the lowest: compound 2; then compound 1; then compounds 3 and 4 (each within the scatter of the next).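

In this assay, among the compounds shown here, the change on the amide-type nitrogen from the group with a six-membered aromatic ring with 1 hetero atom to the one with a six-membered aromatic ring of carbon only gives a 1.3-fold higher number from compound 3 to compound 4 (0.10 log units; within the scatter) and is the first step that stays within the scatter, so the two groups cannot be told apart on this read-out. The other two steps remain beyond the scatter, at a 130-fold higher number from compound 2 to compound 4 (2.10 log units; beyond the scatter) and a 10-fold higher number from compound 1 to compound 4 (1.00 log units; beyond the scatter) and, since compound 2 and compound 3 carry the same ring types yet stand far apart while compound 4 with different ring types stays level with compound 3, the ring types and the counts of hydrogen-bond donors and acceptors do not sort these compounds. No measurement at hand explains why these isomeric groups differ or match.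

What sets compound 2 apart from compound 3 and compound 4 remains unresolved among these few isomers. Also open, as far as these compounds go, is how a methyl group or an amine on the bicyclic group of compound 2 would change the number.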